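Isopropylamino for morpholin-4-yl on the carbonyl carbon

The source may report more compounds than this note shows. Statements on the series, on what has been measured and on what is new or still open speak of the compounds shown alone.

In a functional assay with Oryctolagus cuniculus as the target (a higher number here means a weaker inhibitor, a lower number a stronger inhibitor), compound 1 `COc1ccc(-c2nc(CN(C)C)sc2-c2ccc(OC)cc2)cc1` gives 96 nM and compound 2 `COc1ccc(-c2nc(CNC(=O)N3CCOCC3)sc2-c2ccc(OC)cc2)cc1` gives 660 nM. Compound 2 therefore holds the higher of the two numbers and is the weaker inhibitor of the pair. Among the compounds with values here, the only measured step is a 6.9-fold higher number from compound 1 to compound 2 (0.84 log units; beyond the scatter). It puts ((morpholin-4-yl)carbonyl)amino in place of dimethylamino on a saturated chain carbon bound to an aromatic carbon.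

Compound 3 `COc1ccc(-c2nc(CNC(=O)NC(C)C)sc2-c2ccc(OC)cc2)cc1` differs from compound 2 in one place: isopropylamino in place of morpholin-4-yl on a carbonyl carbon. Isopropylamino stands in place of morpholin-4-yl on a carbonyl carbon, and the carbonyl itself stays. Within the data shown here, the one measured step bears on this change only loosely, as it swaps the whole group and does not vary the substituent on the carbonyl carbon. The data therefore give no direction for the change. A shift smaller than the one seen on going to compound 2, at 660 nM, is expected, most likely none beyond the scatter. The expected step is a 1.3-fold lower number from compound 2 to compound 3 (0.12 log units; within the scatter). Compound 3 is estimated at 500 nM, with an expected range of 150 nM to 1700 nM.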

Compound 3, half-maximal inhibitory concentration: 42 nM
The estimate for compound 3 lay 12-fold (1.08 log units) above the measured number, and the stated range ends above it.
By their numbers in this assay, from the lowest: compound 3; then compound 1; then compound 2.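

In this assay, the group on the carbonyl carbon proves decisive with the carbonyl itself kept: a 16-fold lower number from compound 2 to compound 3 (1.20 log units; beyond the scatter), a change that removes the ring of morpholin-4-yl and brings in the single hydrogen-bond donor of isopropylamino. The urea-type side chain is also no liability in itself, since a 2.3-fold lower number from compound 1 to compound 3 (0.36 log units; beyond the scatter), whereas a 6.9-fold higher number from compound 1 to compound 2 (0.84 log units; beyond the scatter); the loss seen earlier therefore goes with the morpholin-4-yl version and not with every (carbonyl)amino replacement of dimethylamino. No supporting data bear on why isopropylamino and morpholin-4-yl differ so widely here.

From the compounds shown here alone, it remains open whether the hydrogen on the isopropylamino nitrogen or the absence of a ring accounts for the step, and diethylamino on the carbonyl carbon, which has neither, would help to separate the two. Also open, going by these compounds, is whether other open-chain groups on the carbonyl carbon, such as tert-butylamino or n-butylamino, stay close to compound 3 at 42 nM or fall back toward the number of compound 2 at 660 nM.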